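This account rests on a few compounds, and the source may have more. Where it says the series, first, only, none or still open, it means among the compounds named here.

Compound 1, `N#CC1=C(N)N(c2ccc(S(N)(=O)=O)cc2)C2=C(C(=O)CCC2)C1c1ccc([N+](=O)[O-])cc1`, gives 100% in a functional assay on Ehrlich cells (Mus musculus) for antiproliferative activity, read by trypan blue exclusion, with a stated time of 2 h, tested at 100 ug/mL; a lower number here means a weaker effect, a higher number a stronger effect of the compound at the concentration tested. Compound 2, `COc1ccc(C2C(C#N)=C(N)N(c3ccc(S(N)(=O)=O)cc3)C3=C2C(=O)CCC3)c2ccccc12`, gives 90% in this assay.

On the numbers shown, compound 2 stands at the bottom of the two, with compound 1 its only neighbour, the gap between them being a number 10 percentage points lower from compound 1 to compound 2 (within the scatter). Both aryl groups tried so far on that saturated ring carbon thus gave a strong effect at the concentration tested.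

Compound 3, `N#CC1=C(N)N(c2ccc(S(N)(=O)=O)cc2)C2=C(C(=O)CCC2)C1c1ccco1`, has not yet been measured. It differs from compound 2 as follows: furan-2-yl in place of 4-methoxynaphthalen-1-yl on a saturated ring carbon. Among the measured compounds shown here, the only measured step that bears on this change is the one from compound 1 to compound 2, which also exchanged the aryl group on the same saturated ring carbon and amounted to a number 10 percentage points lower from compound 1 to compound 2 (within the scatter). Since that exchange stayed within the scatter, the account expects the step to compound 3 to be small as well, a number 5 percentage points lower from compound 2 to compound 3 (within the scatter), with no direction beyond the scatter to be claimed. In this assay compound 3 is therefore estimated at 85%, in a range from 65% to 100%.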

Compound 3, a percentage reported as activity, at one concentration (the size of the read-out at that concentration, not a potency): 10%
Beside the measured number, compound 3's estimate is 75 percentage points above it, and the stated range ends above it.
By their numbers in this assay, from the lowest: compound 3; then compounds 2 and 1 (each within the scatter of the next).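

In this assay, the saturated ring carbon turns out to be far less forgiving than the first two compounds suggested: furan-2-yl in place of 4-methoxynaphthalen-1-yl amounts to a number 80 percentage points lower from compound 2 to compound 3 (beyond the scatter), and furan-2-yl in place of 4-nitrophenyl amounts to a number 90 percentage points lower from compound 1 to compound 3 (beyond the scatter). Since the rest of the core stays the same in each of these steps, the effect at the concentration tested depends heavily on which ring sits at this one carbon, and the earlier step within the scatter did not reveal this. Nothing shown here explains the loss of effect.

As far as these compounds go, it remains open whether the loss goes with the five-membered ring as such, with its hetero atom, or with the absence of any substituent on that ring; a plain phenyl, a thiophen-2-yl or a 5-nitrofuran-2-yl group on the same carbon would separate these readings. From the compounds shown here alone, because each compound is read at a single concentration, it also remains open how the three would compare across a range of concentrations.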